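Adding a chloro group to compound 1

The source may report more compounds than this note shows. Statements on the series, on what has been measured and on what is new or still open speak of the compounds shown alone.

Compound 1 `O=C1OCC[C@@H]1NC(=S)SCCOc1ccccc1` gives 63800 nM
Compound 2 `CCOc1ccccc1OCCSC(=S)N[C@H]1CCOC1=O` gives 28300 nM

Among the compounds with values here, only two compounds have been measured so far, so any trend rests on very little. In a functional assay on DU-145 cells (Homo sapiens) for antiproliferative activity, read by MTT assay, with a stated time of 72 h (on this read-out lower numbers stand for stronger inhibition and higher numbers for weaker inhibition), compound 1 gives 63800 nM, the higher of the two numbers, which leaves it as the weaker inhibitor of the pair. The next compound to be tested is compound 3 `O=C1OCC[C@@H]1NC(=S)SCCOc1ccc(Cl)cc1`. It differs from compound 1 in one place: chloro in place of hydrogen on an aromatic carbon. In words, this is chloro in place of hydrogen on an aromatic carbon, para to a large group.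

Within the data shown here, only one measured step bears on this change: a 2.3-fold lower number from compound 1 to compound 2 (0.35 log units; beyond the scatter). That step also replaces hydrogen on an aromatic carbon, this time with ethoxy. Since ethoxy and chloro are different groups, this single step is only a loose guide to direction and size. A similarly modest move towards a lower number is therefore expected in this assay, although no change beyond the scatter remains possible. The expected step is a 2.0-fold lower number from compound 1 to compound 3 (0.30 log units; within the scatter). For compound 3 the estimated value is 32000 nM, with an expected range from 13000 nM to 70000 nM.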

Compound 3, half-maximal inhibitory concentration: > 64000 nM
Compound 3 ended at the assay's limit; the forecaster's own chance of this, stated with the estimate: 8%; middle value at least 2.0-fold (0.30 log units) away from the limit.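

In this assay compound 3 gives > 64000 nM, a limit of the assay and not a number, and the only such limit among these compounds: the limit of > 64000 nM in this assay, at which 1 of the 3 values shown sits.

The step reads a number no lower from compound 1 to compound 3 (the limit leaves the size open), so replacing a hydrogen on the aromatic ring does not by itself bring a lower number: ethoxy gave a 2.3-fold lower number from compound 1 to compound 2 (0.35 log units; beyond the scatter), whereas chloro, para to a large group, gave no such gain. How far the number rises with chloro, and whether it rises at all, cannot be read.

The compounds shown leave open whether the difference between these two steps follows from the identity of the group, from where it sits on the ring, or from both, since ethoxy and chloro are not compared at the same place. A methoxy group or an amine para to the large group, or chloro elsewhere on the ring, would help to separate these possibilities.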